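This account rests on a few compounds, and the source may have more. Where it says the series, first, only, none or still open, it means among the compounds named here.

Compound 3 `Cc1cccnc1-c1ccc(C(=O)Nc2ccc(C(C)(C)C)cc2)cc1` gives the lowest number of the three in a functional assay for antagonist activity at transient receptor potential cation channel subfamily V member 1 (Homo sapiens), read by FLIPR (a higher number here means a weaker inhibitor, a lower number a stronger inhibitor), at 11 nM. Among the measured compounds shown here, its nearest neighbour, compound 2 `Cc1cccnc1-c1ccc(C(=O)Nc2ccc(C(C)C)cc2)cc1`, gives 73 nM, and the only single-point step measured is a 6.6-fold lower number from compound 2 to compound 3 (0.82 log units; beyond the scatter), which concerns the saturated chain carbon. Compound 1 `N#Cc1ccc(NC(=O)c2ccc(-c3ncccc3C(F)(F)F)cc2)cc1` gives 417 nM, far above compound 3. Compound 4 `CCS(=O)(=O)Nc1cccnc1-c1ccc(C(=O)Nc2ccc(C(C)(C)C)cc2)cc1` differs from compound 3 by (ethylsulfonyl)amino in place of methyl on an aromatic carbon, placed on an aromatic carbon of the six-membered aromatic ring with one nitrogen, ortho to a large group, two atoms from the ring nitrogen. For the measured compounds named here, no measured step touches this position, so the measured step offers no guide here. The expected step of a 1.4-fold higher number from compound 3 to compound 4 (0.13 log units; within the scatter) is therefore uncertain, with no clear direction. Compound 4 is estimated at 15 nM, within a range from 3 nM to 80 nM.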

Compound 4, half-maximal inhibitory concentration: 49 nM
Compound 4: the middle estimate sits 3.3-fold (0.51 log units) below what was measured; the range from low to high includes it.
By their numbers in this assay, from the lowest: compound 3; then compounds 4 and 2 (each within the scatter of the next); then compound 1.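

In this assay, putting (ethylsulfonyl)amino in place of methyl on this aromatic carbon, ortho to a large group, gives a 4.5-fold higher number from compound 3 to compound 4 (0.65 log units; beyond the scatter), so the position accepts a six-heavy-atom group with only a modest rise in the number. No measurement shown explains that rise. The swap changes size and adds a hydrogen-bond donor and acceptors all at once, and this single step cannot separate them. A plain amine or a methoxy group at this position would show whether the number follows the sulfonyl part or something simpler.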